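The source may report more compounds than this note shows. Statements on the series, on what has been measured and on what is new or still open speak of the compounds shown alone.

Compound 1, `CC(O)(CSc1cc(C(F)(F)F)cc(C(F)(F)F)c1)C(=O)Nc1ccc(C#N)cc1C(F)(F)F`, gives 7760 nM in a functional assay on LNCaP cells (Homo sapiens) for antiproliferative activity, read by fluorescence and propidium iodide staining, with a stated time of 96 h; on this read-out higher numbers stand for weaker inhibition and lower numbers for stronger inhibition.
Compound 2, `CC(O)(CSc1cc(C(F)(F)F)cc(C(F)(F)F)c1)C(=O)Nc1ccc([N+](=O)[O-])cc1C(F)(F)F`, gives 3110 nM in this assay.
Compound 3, `CC(O)(COc1cc(C(F)(F)F)cc(C(F)(F)F)c1)C(=O)Nc1ccc(C#N)cc1C(F)(F)F`, gives 3560 nM in this assay.

Compound 1 and compound 2 differ in one place, (nitro in place of cyano on an aromatic carbon), and this change brought a 2.5-fold lower number from compound 1 to compound 2 (0.40 log units; beyond the scatter). Compound 3 shares the amide side of compound 1 but carries a different core; how the two cores differ is not broken down here. The values of compound 3 and compound 2 lie within the usual scatter of each other, while the value of compound 3 is lower than that of compound 1.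

Compound 4, `CC(O)(COc1cc(C(F)(F)F)cc(C(F)(F)F)c1)C(=O)Nc1ccc([N+](=O)[O-])cc1C(F)(F)F`, is not yet measured. It stands to compound 3 as compound 2 stands to compound 1: nitro in place of cyano on an aromatic carbon. The surroundings of the changed position are described in the same words for both pairs, so this is the same change made on the core of compound 3. Among the compounds with values here, the only guide to its effect is the single step from compound 1 to compound 2, so the expectation for compound 4 rests on one observation and carries that uncertainty. Compound 4 is expected to show a 2.5-fold lower number from compound 3 to compound 4 (0.41 log units; beyond the scatter), a step of about the size seen as a 2.5-fold lower number from compound 1 to compound 2 (0.40 log units; beyond the scatter). On that basis compound 4 is estimated at 1400 nM, with a likely range from 600 nM to 3500 nM.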

Compound 4, half-maximal inhibitory concentration: 24000 nM
Compound 4: the middle estimate sits 17-fold (1.23 log units) below what was measured; measured number above the stated range.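

Carried to the second core, nitro in place of cyano on an aromatic carbon brought a 6.7-fold higher number from compound 3 to compound 4 (0.83 log units; beyond the scatter), so in this assay the change does not keep its direction from one core to the other, and the two steps clearly differ: the same change on two cores in this assay, a 2.5-fold lower number (0.40 log units; beyond the scatter) from compound 1 to compound 2 and a 6.7-fold higher number (0.83 log units; beyond the scatter) from compound 3 to compound 4, 17-fold (1.23 log units) apart, beyond the scatter of two such steps This shows that, for these two pairs, the effect of the change depends on the core that carries it, so a step read on one core could not be transferred to the other. Within the data shown here, it does not show what in the cores produces the reversal, and with only two pairs and a single assay it gives no rule for any further core.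

The compounds shown leave open whether other groups in the same place, such as a chlorine atom, an acetyl group or a sulfonamide, would also behave differently on the two cores, or whether this reversal is confined to the exchange of cyano and nitro. They also leave open how the change would act on a core with a sulfonyl group in place of the link that separates the two cores shown.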